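Arylsulfonyl in Place of Alkylsulfonyl: Liver Microsome Stability

The source may report more compounds than this note shows. Statements on the series, on what has been measured and on what is new or still open speak of the compounds shown alone.

Measured compounds:
compound 1 `CC(C)S(=O)(=O)NC(=O)c1ccc(Nc2nc(NC3(c4ccc(Cl)cc4)CC3)nc(OCC(F)(F)F)n2)cc1` gives 96%
compound 2 `CCS(=O)(=O)NC(=O)c1ccc(Nc2nc(NC3(c4ccc(Cl)cc4)CC3)nc(OCC(F)(F)F)n2)cc1` gives 85%
compound 3 `O=C(NS(=O)(=O)CCNC(=O)C1CC1)c1ccc(Nc2nc(NC3(c4ccc(Cl)cc4)CC3)nc(OCC(F)(F)F)n2)cc1` is reported as "not active" (no number reported)

In an ADME assay on microsomes from liver (Rattus norvegicus) for metabolic stability, with a stated time of 10 min (on this read-out lower numbers stand for a less stable compound and higher numbers for a more stable compound), compound 2 stands lowest of the two numbers; its nearest neighbour is compound 1, reached by a number 11 percentage points lower from compound 1 to compound 2 (beyond the scatter), and compound 3 carries no number at all. Compound 4 `Cc1ccccc1S(=O)(=O)NC(=O)c1ccc(Nc2nc(NC3(c4ccc(Cl)cc4)CC3)nc(OCC(F)(F)F)n2)cc1` differs from compound 2 by 2-methylphenyl in place of ethyl on a sulfonyl sulfur. For the measured compounds named here, the only measured step that touches the sulfonyl substituent is the one from compound 1 to compound 2, and it was modest. A change on the same sulfonyl sulfur toward a larger group is therefore expected to move the read-out little, if at all, beyond the scatter, and compound 4 is estimated at 88%, between 65% and 98%, meaning a number 3 percentage points higher from compound 2 to compound 4 (within the scatter).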

Compound 4, percent of the compound remaining: 100%
Estimate against measurement, compound 4: 12 percentage points below, outside the stated range (above it).
By their numbers in this assay, from the lowest: compound 2; then compounds 1 and 4 (each within the scatter of the next).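

Putting 2-methylphenyl in place of ethyl on the sulfonyl sulfur gives a number 15 percentage points higher from compound 2 to compound 4 (beyond the scatter) in this assay, so this position carries a six-membered aromatic ring with no loss in the read-out. Against isopropyl, the same group gives a number 4 percentage points higher from compound 1 to compound 4 (within the scatter) on that read-out, so the ring and the branched chain cannot be told apart here. No measured information bears on why the read-out behaves this way. The compounds shown leave open how plain phenyl would compare, and with it whether the methyl on the ring matters. They also leave open how a ring carrying a carboxylic acid or an amine would read.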